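The source may report more compounds than this note shows. Statements on the series, on what has been measured and on what is new or still open speak of the compounds shown alone.

Compound 1 `O=S(=O)(Nc1ccc(-c2nc3ccccc3o2)cc1)c1ccccc1F`: > 100000 nM
Compound 2 `O=S(=O)(Nc1ccc(-c2nc3ccccc3o2)cc1)c1cccs1`: 63000 nM

The two measured compounds were tested in an assay on cells for inhibition of HSP60/HSP10 (Homo sapiens), with a stated time of 60 min; on this read-out lower numbers stand for stronger inhibition and higher numbers for weaker inhibition. Compound 1 gives only a limit there, > 100000 nM, and no number. Going by the values given here, compound 2 is the one compound with an actual number, 63000 nM, so it stands as the single anchor among the values shown. Among the compounds with values here, the one measured step, an at least 1.5-fold lower number from compound 1 to compound 2 (0.20 log units; that floor lies within the scatter), rests on that limit of > 100000 nM in this assay, at which 1 of the 2 values shown sits, and so gives only a floor for the change.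

Compound 3 `Cc1ccccc1S(=O)(=O)Nc1ccc(-c2nc3ccccc3o2)cc1` is not yet measured. It differs from compound 2 by 2-methylphenyl in place of thiophen-2-yl on a sulfonyl sulfur. Within the data shown here, the only step that bears on this change is the one from a phenyl-type ring to the thiophen-2-yl ring, and it is no larger than a floor inside the scatter. Returning to a six-membered carbon ring is therefore expected to bring at best a small rise in the number, a 1.6-fold higher number from compound 2 to compound 3 (0.20 log units; within the scatter), and possibly only a limit. For compound 3 the estimate in this assay is 100000 nM, within 40000 nM to 300000 nM.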

Compound 3, half-maximal inhibitory concentration: 85000 nM
Beside the measured number, compound 3's estimate is 1.2-fold (0.07 log units) above it; the measured number falls inside the stated range.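

In this assay, the change of ring on the sulfonyl sulfur can now be read between two actual numbers rather than against a limit, and the result is a 1.3-fold higher number from compound 2 to compound 3 (0.13 log units; within the scatter) with no further qualification. At this place, therefore, 2-methylphenyl, a six-membered aromatic ring of carbon only, and thiophen-2-yl, a five-membered aromatic ring with a hetero atom, cannot be told apart. Methyl in place of fluoro on an aromatic carbon gives an at least 1.1-fold lower number from compound 1 to compound 3 (0.07 log units; that floor lies within the scatter) and so shows no more than a floor, which rests on a limit: the limit of > 100000 nM in this assay, at which 1 of the 3 values shown sits.

All the groups shown on the sulfonyl sulfur are aromatic rings, so it remains open what an amine, a carboxylic acid or a longer chain would do there. No step shown yet lies beyond the scatter, so it is also open whether this position can move the number at all.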